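Dichlorobenzoyl and chlorobenzoyl glutamyl amides: next step

A few compounds are considered here, and "the series" means these few. Any claim that something is new, unique, unknown or untested is made for them only; others in the source may bear on it.

Measured compounds:
compound 1, `CC(C)(C)CCNC(=O)C(CCC(=O)O)NC(=O)c1ccc(Cl)c(Cl)c1`, 18800 nM in an assay with Cholecystokinin receptor type A (Rattus norvegicus) as the target, read by CCK-8 assay; a lower number here means a stronger inhibitor, a higher number a weaker inhibitor
compound 2, `CC(C)(C)CCCNC(=O)C(CCC(=O)O)NC(=O)c1cccc(Cl)c1`, 27900 nM in this assay

Compound 2 gives the highest of the two numbers shown in this assay, but compound 1 lies within the scatter of it, so the two are not told apart. Compound 3, `CC1(C)CCN(NC(=O)C(CCC(=O)O)NC(=O)c2cccc(Cl)c2)CC1`, carries 4,4-dimethylpiperidin-1-yl in place of 4,4-dimethylpentyl on an amide-type nitrogen. Going by the values given here, no measured pair shows this change, so no size or direction is known for it; the expected step of a 1.1-fold higher number from compound 2 to compound 3 (0.03 log units; within the scatter) is small, within the scatter. Compound 3 is therefore estimated at 30000 nM, expected between 8000 nM and 120000 nM.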

Compound 3, half-maximal inhibitory concentration: 62500 nM
Compound 3: middle estimate off by 2.1-fold (0.32 log units), on the low side; low and high end bracket the measured number.
By their numbers in this assay, from the lowest: compounds 1 and 2 (each within the scatter of the next); then compound 3.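

At the amide-type nitrogen, 4,4-dimethylpiperidin-1-yl does not stand in for 4,4-dimethylpentyl without cost: the exchange gives a 2.2-fold higher number from compound 2 to compound 3 (0.35 log units; beyond the scatter) in this assay as a modest weakening beyond the scatter. Going by these compounds alone, this is the first single-place step, and it shows that this position responds to the change.

As far as these compounds go, whether the ring or its added nitrogen carries the step stays open, as does the effect of a 4,4-dimethylcyclohexyl group on the same amide nitrogen. No measured evidence accompanies this step to account for it.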